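The compounds below may be only part of what the source reports. "The series", "measured", "known", "first", "only" and "open" are said of these compounds alone.

Working notes on the series. Cytotoxicity is read in an ADME assay on MRC5 cells (Homo sapiens), read by MTT assay, with a stated time of 72 h; a higher number here means a weaker inhibitor, a lower number a stronger inhibitor. Within the data shown here, compound 1, `C#Cc1cn([C@@H]2O[C@H](CO)[C@@H](O)[C@H]2O)c2ncnc(N(C)C)c12`, is the only member with a numerical reading: in this assay compound 1 gives 36100 nM. Compound 2, `Cc1ncnc2c1c(-c1cccs1)cn2[C@@H]1O[C@H](CO)[C@@H](O)[C@H]1O`, sits at a limit of the assay rather than at a number: in this assay compound 2 gives > 100000 nM. That limit is the limit of > 100000 nM in this assay, at which 1 of the 2 values shown sits. Among the measured compounds shown here, with one number and one limit, no step between measured compounds can be stated.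

The next compound, compound 3, `CN(C)c1ncnc2c1c(-c1cccs1)cn2[C@@H]1O[C@H](CO)[C@@H](O)[C@H]1O`, is not yet measured. It differs from compound 2 by dimethylamino in place of methyl on an aromatic carbon. For the measured compounds named here, the dimethylamino that enters is the same group that compound 1 carries, and compound 1 is the one member that returns a number rather than a limit. For compound 3 a shift toward a numerical reading is expected, with an at least 1.6-fold lower number from compound 2 to compound 3 (0.22 log units; that floor lies within the scatter), though a second limit would not be surprising. The estimate for compound 3 in this assay is 60000 nM, with a range of 20000 nM to 150000 nM.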

Compound 3, half-maximal inhibitory concentration: > 100000 nM
Compound 3: a limit, no number (the forecaster's own chance of this, stated with the estimate: 40%); at least 1.6-fold (0.22 log units) between middle value and limit.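

Dimethylamino on this aromatic carbon does not by itself give a numerical reading: compound 3 carries that group and still sits at a limit of the assay, as the methyl compound does. Among these compounds, with dimethylamino held fixed, thiophen-2-yl in place of ethynyl gives an at least 2.7-fold higher number from compound 1 to compound 3 (0.44 log units; beyond the scatter) in this assay, and this is the only readable step, so for now the number in compound 1 goes with ethynyl rather than with dimethylamino alone. The change from methyl to dimethylamino cannot be given a size, and neither can any other step between the two limit compounds, because both ends sit at the same limit: the limit of > 100000 nM in this assay, at which 2 of the 3 values shown sit.

Still open, going by these compounds, is whether any group on this aromatic carbon, such as a primary amine, a methoxy group or a longer alkyl chain, brings a thiophen-2-yl compound back to a number. Also open, on these data alone, is whether methyl gives a number alongside ethynyl, and whether a group other than thiophen-2-yl, such as phenyl or a small alkyl chain, also moves the dimethylamino compounds to a limit.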